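Enaminone chalcone series: removing the anilino chloro

A few compounds are considered here, and "the series" means these few. Any claim that something is new, unique, unknown or untested is made for them only; others in the source may bear on it.

Measured so far:
compound 1, `COc1ccc(/C=C/C(=O)c2sc(Nc3ccc(Cl)cc3)nc2C)cc1`, in a functional assay on NCI-H460 cells (Homo sapiens) for cytotoxicity, read by MTT assay; on this read-out lower numbers stand for stronger inhibition and higher numbers for weaker inhibition: > 25000 nM
compound 2, `Cc1nc(Nc2ccc(Cl)cc2)sc1C(=O)/C=C/c1ccccc1`, in this assay: > 25000 nM
compound 3, `COc1cc(/C=C/C(=O)c2sc(Nc3cccc(Cl)c3)nc2C)cc(OC)c1OC`, in this assay: > 25000 nM

Every value shown is a limit of this assay and not a number; compound 2 therefore stands nowhere in particular on the numbers, it sits at the limit like the other two. Among the compounds with values here, the only step between neighbours that differ in one place, a step that the two limits leave unreadable from compound 1 to compound 2, is left unreadable because of the limit of > 25000 nM in this assay, at which 3 of the 3 values shown sit.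

Compound 4, `Cc1nc(Nc2ccccc2)sc1C(=O)/C=C/c1ccccc1`, differs from compound 2 by hydrogen in place of chloro on an aromatic carbon. Within the data shown here, no measured step removes a chloro, and the one measured step carries no readable size, so the expectation for compound 4 rests only on where the three measured compounds stand. The step from compound 2 to compound 4 is therefore expected to be none that this assay can read, a step that the limit leaves unreadable from compound 2 to compound 4. Compound 4 is expected to give 30000 nM, within 8000 nM to 100000 nM, most likely again as a limit.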

Compound 4, half-maximal inhibitory concentration: > 25000 nM
Compound 4 was reported as a limit; the forecaster's own chance of this, stated with the estimate: 80%; the middle value does not contradict the limit.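

No new step can be read from compound 2 to compound 4 in this assay, because both values are limits and not numbers: the limit of > 25000 nM in this assay, at which 4 of the 4 values shown sit.

The compounds shown leave open whether hydrogen in place of chloro changes the cytotoxicity of the shared core at all.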